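Swapping a Pyrimidine Ring for a Trifluoromethylphenyl Ring

A few compounds are considered here, and "the series" means these few. Any claim that something is new, unique, unknown or untested is made for them only; others in the source may bear on it.

Compound 1 `CC(C)CN(CC(C)C)c1ccc(/C(=N/O)Nc2ccc(F)c(Br)c2)cc1NC(=O)NC1CCCCC1`: in an assay on isolated protein for inhibition of Indoleamine 2,3-dioxygenase 1 (Homo sapiens) (on this read-out lower numbers stand for stronger inhibition and higher numbers for weaker inhibition), compound 1 gives > 3000 nM, which is a limit of the assay, not a number.
Compound 2 `CC(C)CN(CC(C)C)c1ccc(/C(=N/O)Nc2ccc(F)c(Br)c2)cc1NC(=O)Nc1cncnc1`: in this assay compound 2 gives > 3000 nM, again only a limit.

Compound 2 therefore stands at the assay limit, with no number known for it. Compound 3 `CC(C)CN(CC(C)C)c1ccc(/C(=N/O)Nc2ccc(F)c(Br)c2)cc1NC(=O)Nc1ccc(C(F)(F)F)cc1` differs from compound 2 in one place: 4-(trifluoromethyl)phenyl in place of pyrimidin-5-yl on an amide-type nitrogen. Within the data shown here, the only measured step, a step that the two limits leave unreadable from compound 1 to compound 2, is unreadable since both values sit at the limit (the limit of > 3000 nM in this assay, at which 2 of the 2 values shown sit), so no measured step bears on this new change, and no direction or size can be taken from these data. For compound 3 the expected result in this assay is 3000 nM, between 500 nM and 20000 nM. This estimate corresponds to a number no higher from compound 2 to compound 3 (the limit leaves the size open).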

Compound 3, half-maximal inhibitory concentration: > 3000 nM
Compound 3 gave a limit, no number; the forecaster's own chance of this, stated with the estimate: 60%; the middle value sits exactly at the limit.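

No step between compound 1, compound 2 and compound 3 can be read, since each gives only a limit of the assay and not a number: the limit of > 3000 nM in this assay, at which 3 of the 3 values shown sit.

The compounds shown leave open how strongly any of them inhibits, and whether the group on the amide-type nitrogen changes that.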